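A Biaryl Swap Weighed Against Three Lipophilicity Readings

The source may hold more compounds than are shown below. What is called first, only, known or untested is meant among the compounds shown, and "the series" means these compounds.

Compound 1, `CC[C@@H](Nc1c(C#N)c(-c2ccc(-c3cccc(Cl)c3F)cc2)nc2cnccc12)C(N)=O`, measured in a physicochemical assay for lipophilicity, read by HPLC, at pH 7.5 (on this read-out lower numbers stand for lower lipophilicity and higher numbers for higher lipophilicity), gives 3.1.
Compound 2, `CN(CC(N)=O)c1c(C#N)c(-c2ccc(Br)cc2)nc2cnccc12`, gives 2.1.
Compound 3, `CC[C@@H](Nc1c(C#N)c(-c2ccc(-c3cccc(Cl)c3F)cc2)nc2cnccc12)C(=O)O`, gives 2.2.

Among these three numbers compound 1 stands highest. Its nearest neighbour is compound 3, reached by a number 0.90 log units lower from compound 1 to compound 3 (beyond the scatter), a change at the carbonyl end of the side chain only. Compound 2 lies furthest away; it differs from compound 1 in several places at once, so its lower value cannot be tied to any single part of the molecule.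

Compound 4, `CC[C@@H](Nc1c(C#N)c(-c2ccc(-c3ccccc3C(F)(F)F)cc2)nc2cnccc12)C(N)=O`, has not been measured. It differs from compound 1 in the outer ring of the biaryl: 2-(trifluoromethyl)phenyl in place of 3-chloro-2-fluorophenyl on an aromatic carbon. Neither measured step touches that outer ring. The step from compound 1 to compound 3 alters the side-chain carbonyl, and the gap between compound 2 and compound 1 mixes changes together, so nothing shown isolates what swapping one halogenated ring for another does in this assay. With a group of similar size leaving and entering, and no donors or acceptors gained or lost, the expectation is a step no larger than the scatter, in no firm direction; the expected step is a number 0.10 log units lower from compound 1 to compound 4 (within the scatter). Compound 4 is therefore estimated at 3, between 2.6 and 3.4.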

Compound 4, distribution coefficient: 3.1
For compound 4 the middle estimate is 0.10 log units below the measured one, and the stated range covers the measured number.
By their numbers in this assay, from the lowest: compounds 2 and 3 (each within the scatter of the next); then compounds 1 and 4 (each within the scatter of the next).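

Among the compounds shown here, replacing 3-chloro-2-fluorophenyl with 2-(trifluoromethyl)phenyl on this aromatic carbon gives no change at the digits printed from compound 1 to compound 4 (within the scatter), so in this assay this pair offers the only direct look at the outer ring of the biaryl. The change is not a trivial one on paper, as 10 heavy atoms enter where 8 leave and chlorine disappears, yet its step stands apart from the side-chain change, a number 0.90 log units lower from compound 1 to compound 3 (beyond the scatter), which lies beyond the scatter. For this one pair, then, the outer ring can be exchanged without a measurable shift in the read-out, and no measurement here explains why the two rings read alike.

On these data alone, both rings carry only carbon and halogen substituents, so it remains open whether an outer ring bearing an amine or a carboxylic acid would leave the number equally unmoved. As far as these compounds go, it is also open whether the same ring exchange would give a similar result on the carboxylic acid side chain of compound 3, or whether the outcome seen here holds only alongside the primary amide of compound 1.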